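Chloro on the propanoyl chain of compound 2

A few compounds are considered here, and "the series" means these few. Any claim that something is new, unique, unknown or untested is made for them only; others in the source may bear on it.

Values so far in a physicochemical assay for lipophilicity, measured as octanol-water partition; on this read-out higher numbers stand for higher lipophilicity and lower numbers for lower lipophilicity
- Compound 1 `CC(C)[C@@H]1CC[C@@H](C)C[C@H]1OC(=O)c1ccc(Cl)cc1` gives 5.34
- Compound 2 `CCC(=O)O[C@@H]1C[C@H](C)CC[C@H]1C(C)C` gives 3.54
- Compound 3 `CC(C)[C@@H]1CC[C@@H](C)C[C@H]1OC(=O)/C=C/c1ccccc1[N+](=O)[O-]` gives 5.18

Compound 2 stands lowest of these three numbers. Compound 3 is the nearest to it and compound 1 the furthest, and both gaps lie beyond the scatter.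

The next compound to be measured is compound 4 `CC(Cl)C(=O)O[C@@H]1C[C@H](C)CC[C@H]1C(C)C`, which differs from compound 2 in one place: chloro in place of hydrogen on a saturated chain carbon bound to a carbonyl carbon and a saturated chain carbon. This is chloro in place of hydrogen on a saturated chain carbon bound to a carbonyl carbon and a saturated chain carbon. Cut one bond further out, the same difference reads propanoyl to (1-chloroethyl)carbonyl.

Within the data shown here, no two measured compounds differ in only one place, so no measured step sets the size of this one. Compound 1 also carries a chloro group, but it differs from compound 2 in more than that, and its gap to compound 2 cannot be assigned to chloro alone. A modest rise is expected, estimated as a number 0.41 log units higher from compound 2 to compound 4 (beyond the scatter) and only a little beyond the scatter. The estimate for compound 4 is 3.95 with an expected range from 3.6 to 4.3 in this assay.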

Compound 4, partition coefficient: 4.04
Estimate against measurement, compound 4: 0.09 log units below; the measured number falls inside the stated range.
By their numbers in this assay, from the lowest: compound 2; then compound 4; then compounds 3 and 1 (each within the scatter of the next).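

In this assay, the series now has its first measured change in a single place: chloro in place of hydrogen on a saturated chain carbon bound to a carbonyl carbon and a saturated chain carbon gives a modest rise (a number 0.50 log units higher from compound 2 to compound 4 (beyond the scatter)). Compound 1 and compound 3 differ from compound 2 in more than one place, so this pair alone gives a size for the change from propanoyl to (1-chloroethyl)carbonyl, and that size lies beyond the scatter. No available evidence bears on the origin of this step.

A single replacement at a single position shows neither how chloro compares with another group on the same carbon, such as fluoro, a hydroxyl, an amine or a methoxy group, nor how far the step depends on the group chosen. From the compounds shown here alone, it also remains open whether chloro in place of hydrogen gives a step of similar size on a longer chain, such as butanoyl, or at a different carbon of the chain.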